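This account rests on a few compounds, and the source may have more. Where it says the series, first, only, none or still open, it means among the compounds named here.

Measured compounds in a functional assay on CAKI-1 cells (Homo sapiens) for inhibition, read by sulforhodamine B assay, with a stated time of 48 h; on this read-out lower numbers stand for stronger inhibition of growth and higher numbers for weaker inhibition of growth:
Compound 1 `COc1cc(-c2nn(-c3cccc(NC(=O)c4ccc(Cl)c(C(F)(F)F)c4)c3)cc2-c2ccncc2)ccc1Cl` gives only the limit > 32500 nM in this assay.
Compound 2 `O=C(Nc1cccc(-n2cc(-c3ccncc3)c(-c3ccc(Cl)c(O)c3)n2)c1)Nc1cc(C(F)(F)F)cc(C(F)(F)F)c1` gives 4420 nM in this assay.
Compound 3 `COc1cc(-c2nn(-c3cccc(NC(=O)c4ccccc4)c3)cc2-c2ccncc2)ccc1Cl` gives only the limit > 100000 nM in this assay.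

Among the compounds with values here, compound 2 is thus the one compound with an actual number; the other two values are limits of this assay and not numbers. Within the data shown here, the single one-place step, from compound 1 to compound 3 a step that the two limits leave unreadable from compound 1 to compound 3, cannot be sized, because the limit of > 100000 nM in this assay, at which 1 of the 3 values shown sits, and the limit of > 32500 nM in this assay, at which 1 of the 3 values shown sits, cap both of its ends.

Compound 4 `O=C(Nc1cccc(-n2cc(-c3ccncc3)c(-c3ccc(Cl)c(O)c3)n2)c1)Nc1cccc(C(F)(F)F)c1` differs from compound 2 by hydrogen in place of trifluoromethyl on an aromatic carbon, on the urea side of the shared core. Among the measured compounds shown here, no measured step touches that part of the molecule, and the only measured step is unreadable, so nothing measured here points to a direction. The expectation is therefore a step in this assay within the usual scatter, leaning if anything toward slightly weaker inhibition of growth. Compound 4 is expected near 6000 nM, within a range from 2500 nM to 16000 nM. The expected step of a 1.4-fold higher number from compound 2 to compound 4 (0.13 log units; within the scatter) would stay within the scatter of repeated measurements.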

Compound 4, concentration for total growth inhibition: > 32500 nM
Compound 4 gave a limit, no number; the forecaster's own chance of this, stated with the estimate: 10%; middle value at least 5.4-fold (0.73 log units) away from the limit.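

In this assay, within the data shown here, a change on the urea side of the molecule can now be sized for the first time: hydrogen in place of one trifluoromethyl group gives an at least 7.3-fold higher number from compound 2 to compound 4 (0.86 log units; beyond the scatter). So this position on the aromatic ring is not indifferent, and with both trifluoromethyl groups present, compound 2 remains the only compound shown with an actual number. Compound 4 gives only a limit, and it shares that limit with compound 1: the limit of > 32500 nM in this assay, at which 2 of the 4 values shown sit.

As far as these compounds go, the true size of the step stays open: the value for compound 4 is a limit, not a number, and the step from compound 1 to compound 3 likewise cannot be read. Also open, from the compounds shown here alone, is whether a methyl group or a nitrile at this position would keep the growth inhibition seen with compound 2.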